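This account rests on a few compounds, and the source may have more. Where it says the series, first, only, none or still open, it means among the compounds named here.

Compound 1 `O=C1CS/C(=N\c2csc(-c3ccccc3)c2)N1` and compound 2 `O=C1N/C(=N/c2csc(-c3ccc(Cl)cc3)c2)S/C1=C\c1ccccc1` were both tested in a functional assay on SW-620 cells (Homo sapiens) for cytotoxicity, read by MTT assay, with a stated time of 72 h; on this read-out higher numbers stand for weaker inhibition and lower numbers for stronger inhibition. Compound 1 gives > 50000 nM, which is a limit of the assay rather than a number. Compound 2 likewise gives > 50000 nM, again a limit. Compound 2 thus stands where every value shown sits, namely (the limit of > 50000 nM in this assay, at which 2 of the 2 values shown sit). Compound 3 `Cc1ccc(/C=C2\S/C(=N\c3csc(-c4ccc(Cl)cc4)c3)NC2=O)cc1` differs from compound 2 by methyl in place of hydrogen on an aromatic carbon. Among the compounds with values here, no step between measured compounds is available, so the expected step that the limit leaves unreadable from compound 2 to compound 3 is none beyond the scatter. Compound 3 is therefore estimated at 60000 nM, within 20000 nM to 200000 nM, and most likely reported only as a limit.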

Compound 3, half-maximal inhibitory concentration: 1500 nM
Beside the measured number, compound 3's estimate is 40-fold (1.60 log units) above it, and the stated range ends above it.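

In this assay the change from phenyl to 4-methylphenyl gives an at least 33-fold lower number from compound 2 to compound 3 (1.52 log units; beyond the scatter) and so shows that this aromatic carbon responds strongly to a single added methyl. The earlier compounds shown here gave no measured number to compare, whereas compound 3 gives one. Compound 2 gives only a limit, so the full size of this step cannot be read: the limit of > 50000 nM in this assay, at which 2 of the 3 values shown sit.

Going by these compounds, whether an ethyl group, a methoxy group or an amine at this carbon would act like methyl stays open. So does whether methyl would have the same effect elsewhere on this ring.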